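Swapping Trifluoromethyl for Chloro on the Anilide Ring

This account rests on a few compounds, and the source may have more. Where it says the series, first, only, none or still open, it means among the compounds named here.

Compound 2 `O=C(Nc1cccc(C(F)(F)F)c1)c1cc(Cl)ccc1O` stands at the top of the three measured numbers in an assay on cells for antagonist activity at P2X purinoceptor 7 (Homo sapiens), read by fluorescence and calcium flux, with a stated time of 30 min; a lower number here means a stronger inhibitor, a higher number a weaker inhibitor: compound 2 gives 6320 nM, while compound 1 `O=C(Nc1cc(C(F)(F)F)cc(C(F)(F)F)c1)c1cccc(F)c1O` gives 857 nM and compound 3 `O=C(Nc1cc([N+](=O)[O-])cc(C(F)(F)F)c1)c1cc(Cl)ccc1O` gives 143 nM. Among the measured compounds shown here, the one single-point step among the measured compounds is a 44-fold lower number from compound 2 to compound 3 (1.65 log units; beyond the scatter), a nitro in place of hydrogen on an aromatic carbon, and it is large. Compound 4 `O=C(Nc1cccc(Cl)c1)c1cc(Cl)ccc1O` differs from compound 2 by chloro in place of trifluoromethyl on an aromatic carbon, sitting on an aromatic carbon of a six-membered aromatic ring of carbon only, meta to a large group. For the measured compounds named here, no measured pair shows this exchange, and the nitro step does not bear on it directly, so there is no basis for a step beyond the scatter in this assay in either direction. The expected step is therefore a 1.1-fold higher number from compound 2 to compound 4 (0.04 log units; within the scatter). Compound 4 is estimated at 7000 nM, with a range from 2500 nM to 20000 nM.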

Compound 4, half-maximal inhibitory concentration: 599 nM
Beside the measured number, compound 4's estimate is 12-fold (1.07 log units) above it; the whole stated range lies above it.
By their numbers in this assay, from the lowest: compound 3; then compounds 4 and 1 (each within the scatter of the next); then compound 2.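

In this assay, chloro in place of trifluoromethyl gives an 11-fold lower number from compound 2 to compound 4 (1.02 log units; beyond the scatter), so this position, on an aromatic carbon meta to a large group, responds strongly to the group it carries. The step comes with a fall from 4 heavy atoms to 1, while the counts of hydrogen-bond donors and acceptors and the net charge stay the same, so a large gain here does not need a change in any of those counts. Nothing at hand explains why the exchange has this effect.

The compounds shown leave open whether bromo, methyl, methoxy or a nitrile at this position would give a number closer to that of compound 4 or of compound 2. They also leave open whether the same exchange keeps its size on a ring that also carries a nitro group.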